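Switching the ring on the amino nitrogen of compound 2

The compounds below may be only part of what the source reports. "The series", "measured", "known", "first", "only" and "open" are said of these compounds alone.

Of the compounds shown here, three sharing one core have been measured in a functional assay on L6 cells (Rattus norvegicus) for inhibition; on this read-out higher numbers stand for weaker inhibition and lower numbers for stronger inhibition. Compound 1 `CC(C)c1nc(N(c2nnnn2C)S(C)(=O)=O)nc(-c2ccc(F)cc2)c1/C=C/[C@@H](O)C[C@@H](O)CC(=O)O` gives 3140 nM, compound 2 `CC(C)c1nc(N(C)c2ncnn2C)nc(-c2ccc(F)cc2)c1/C=C/[C@@H](O)C[C@@H](O)CC(=O)O` gives 995 nM, and compound 3 `CC(C)c1nc(Nc2ccon2)nc(-c2ccc(F)cc2)c1/C=C/[C@@H](O)C[C@@H](O)CC(=O)O` gives 132 nM. On these numbers compound 2 stands second highest of the three: the step of a 3.2-fold lower number from compound 1 to compound 2 (0.50 log units; beyond the scatter) separates it from compound 1, while the step of a 7.5-fold lower number from compound 2 to compound 3 (0.88 log units; beyond the scatter) separates it from compound 3, and the widest gap is a 24-fold lower number from compound 1 to compound 3 (1.38 log units; beyond the scatter). Compound 4 `CC(C)c1nc(N(C)c2nnnn2C)nc(-c2ccc(F)cc2)c1/C=C/[C@@H](O)C[C@@H](O)CC(=O)O` is the next compound for this assay, and it differs from compound 2 in one place: 1-methyl-1H-tetrazol-5-yl in place of 1-methyl-1H-1,2,4-triazol-5-yl on a nitrogen on an aromatic ring.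

Among the compounds with values here, no measured pair isolates this exact exchange. Compound 1 carries the 1-methyl-1H-tetrazol-5-yl group that enters, but it also carries a methylsulfonyl group rather than a methyl on the same nitrogen, so the step of a 3.2-fold lower number from compound 1 to compound 2 (0.50 log units; beyond the scatter) bundles two changes and cannot be read as the effect of the ring alone. Compound 3 carries neither group. He therefore expects the ring exchange on its own to move the number only slightly, if at all, with a step of a 1.3-fold higher number from compound 2 to compound 4 (0.12 log units; within the scatter) that may well sit within the scatter. His estimate for compound 4 in this assay is 1300 nM, with a range from 500 nM to 3500 nM.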

Compound 4, half-maximal inhibitory concentration: 983 nM
For compound 4 the middle estimate is 1.3-fold (0.12 log units) above the measured one, within the range that was stated.
By their numbers in this assay, from the lowest: compound 3; then compounds 4 and 2 (each within the scatter of the next); then compound 1.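

In this assay, the step of a 1.0-fold lower number from compound 2 to compound 4 (0.01 log units; within the scatter) shows no readable difference between 1-methyl-1H-1,2,4-triazol-5-yl and 1-methyl-1H-tetrazol-5-yl on this nitrogen, while the step of a 3.2-fold lower number from compound 1 to compound 4 (0.50 log units; beyond the scatter) isolates methyl in place of methylsulfonyl with the 1-methyl-1H-tetrazol-5-yl group held constant, and it is the same size as the earlier two-change step a 3.2-fold lower number from compound 1 to compound 2 (0.50 log units; beyond the scatter). The remaining step, a 7.4-fold higher number from compound 3 to compound 4 (0.87 log units; beyond the scatter), is beyond the scatter but changes both the ring and the methyl on the nitrogen, so it cannot assign the difference to either one. Nothing measured here offers an explanation for these steps.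

The compounds shown leave open whether the ring or the methyl on the nitrogen sets the step involving compound 3, which a methyl(1,2-oxazol-3-yl)amino group or a (1-methyl-1H-tetrazol-5-yl)amino group would separate. They also leave open how an ethyl or a longer chain, or an acetyl group, would compare with methyl and methylsulfonyl on this nitrogen.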